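The source may hold more compounds than are shown below. What is called first, only, known or untested is meant among the compounds shown, and "the series" means these compounds.

The measured compounds so far:

compound 1, `CC(C)CNC(=O)n1c(=O)oc2c(C3CCN(C)CC3)cccc21`: 535 nM
compound 2, `CN1CCC(c2ccc3c(c2)oc(=O)n3C(=O)NCCCCc2ccccc2)CC1=O`: 105 nM
compound 3, `CCCCCNC(=O)n1c(=O)oc2cc(-c3ccc(F)cc3)ccc21`: 60 nM

All three were tested in an assay on HEK293 cells for inhibition of acid ceramidase (Homo sapiens), read by fluorescence, with stated times of 10 min and 3 h; on this read-out higher numbers stand for weaker inhibition and lower numbers for stronger inhibition. Compound 2 gives the second highest of the three numbers. Compound 3 gives 60 nM, a lower number, but the gap to compound 2 lies within the usual scatter, so the two cannot be told apart. Compound 1 gives 535 nM, a higher number, and that gap is beyond the scatter, so compound 1 is the weaker inhibitor of that pair.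

The next compound, compound 4, `CN1CCN(c2ccc3c(c2)oc(=O)n3C(=O)NCCCCc2ccccc2)C(=O)C1`, differs from compound 2 in one place: 4-methyl-2-oxopiperazin-1-yl in place of 1-methyl-2-oxopiperidin-4-yl on an aromatic carbon. The ring that leaves and the ring that enters are the same size and carry the same count of heavy atoms; the one that enters holds one more hetero atom and one more hydrogen-bond acceptor. Within the data shown here, no pair of measured compounds shows the effect of this kind of exchange, so there is no measured step to lean on. The expectation for compound 4 in this assay is a small step, if any, toward a slightly higher number, most likely within the scatter, as a 1.4-fold higher number from compound 2 to compound 4 (0.15 log units; within the scatter). Compound 4 is therefore estimated at 150 nM, with a range from 50 nM to 500 nM.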

Compound 4, half-maximal inhibitory concentration: 52 nM
The estimate for compound 4 lay 2.9-fold (0.46 log units) above the measured number; the measured number falls inside the stated range.
By their numbers in this assay, from the lowest: compounds 4, 3 and 2 (each within the scatter of the next, the first and the last beyond it); then compound 1.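

Where the shared core carries a six-membered ring on this aromatic carbon, the exchange of 1-methyl-2-oxopiperidin-4-yl for 4-methyl-2-oxopiperazin-1-yl gives in this assay a 2.0-fold lower number from compound 2 to compound 4 (0.31 log units; beyond the scatter) and so goes a modest way toward stronger inhibition. Among these compounds, this is the first measured step at this place, and it shows that a ring of the same size and the same count of heavy atoms, holding one more hetero atom, is tolerated here with no loss of inhibition. Nothing available explains why the number falls with this change.

As far as these compounds go, how a morpholine ring or a piperazine ring without the carbonyl would behave at this place remains open. So does whether the same exchange would give a similar step with a different chain on the core.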